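A Ring Swapped for a Chain on Compound 1

This account rests on a few compounds, and the source may have more. Where it says the series, first, only, none or still open, it means among the compounds named here.

Of the compounds shown here, two have numbers so far: compound 1 (`CCc1cccc(CC)c1N1CCn2cc(-c3nc(Nc4ccc(N5CCC(N6CCN(C)CC6)CC5)cc4OC)nc4[nH]ccc34)cc2C1=O`) and compound 2 (`CCc1cccc(CC)c1N1CCn2cc(-c3nc(Nc4ccc(N5CCN(CC(=O)N(C)C)CC5)cc4OC)nc4[nH]ccc34)cc2C1=O`). In a functional assay on CAL-51 cells (Homo sapiens) for inhibition, read by luminescence, with a stated time of 3 days (a lower number here means a stronger inhibitor, a higher number a weaker inhibitor), compound 1 gives 9 nM and compound 2 gives 11 nM as their half-maximal inhibitory concentrations. These two numbers lie within the usual scatter of repeated measurements, so compound 1 stands level with compound 2.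

Compound 3 (`CCc1cccc(CC)c1N1CCn2cc(-c3nc(Nc4ccc(N5CCC(C(=O)N(C)CCN(C)C)CC5)cc4OC)nc4[nH]ccc34)cc2C1=O`) has not yet been measured. It keeps the core of compound 1 but carries (2-(dimethylamino)ethyl)(methyl)carbamoyl in place of 4-methylpiperazin-1-yl on a saturated ring carbon. Within the data shown here, no two measured compounds differ in just one place, so the data offer no direct guide to this change. Among the measured compounds shown here, the only anchor is compound 2 at 11 nM within the scatter of compound 1.

The estimated step of a 1.6-fold higher number from compound 1 to compound 3 (0.19 log units; within the scatter) is expected to stay within the scatter, with a slight lean toward a weaker inhibitor. Compound 3 is expected to give 14 nM with an estimated range of 5 nM to 40 nM in this assay once tested.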

Compound 3, half-maximal inhibitory concentration: 7 nM
Compound 3: middle estimate off by 2.0-fold (0.30 log units), on the high side; the measured number falls inside the stated range.
By their numbers in this assay, from the lowest: compounds 3, 1 and 2 (each within the scatter of the next).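

In this assay, replacing 4-methylpiperazin-1-yl on a saturated ring carbon with (2-(dimethylamino)ethyl)(methyl)carbamoyl gives a 1.3-fold lower number from compound 1 to compound 3 (0.11 log units; within the scatter). Among these compounds, this is the only direct reading of a change at this position, which compound 2 could not give, as it differs from compound 1 in more than one place. It shows that, in this pair, a chain with no ring and with a carbonyl can take the place of the 4-methylpiperazin-1-yl ring and stay level with it, although nothing measured here tells why the two groups read alike.

Going by these compounds, what the chain needs in order to stay level remains open, since a single step cannot separate the part played by the carbonyl from that of the dimethylamino end. A carboxylic acid in place of the dimethylamino end, or a chain longer by one carbon, would test how much of this chain can vary before the number in this assay moves beyond the usual scatter.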